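The compounds below may be only part of what the source reports. "The series", "measured", "known", "first", "only" and "open" are said of these compounds alone.

Compound 1 `O=C(Nc1ccc(S(=O)(=O)Nc2ccccc2)cc1)c1cc(F)c(Cl)cc1F`: 37%
Compound 2 `O=C(Nc1ccc(Cl)cc1Cl)c1ccc(S(=O)(=O)Nc2ccccc2)cc1`: "not determined" (no result reported)
Compound 3 `Cc1ccc(NS(=O)(=O)c2ccc(NC(=O)c3ccc(Cl)cc3Cl)cc2)cc1`: "not determined" (no result reported)

For the measured compounds named here, in a functional assay on HEK293 cells for agonist activity at probable G-protein coupled receptor 27 (Homo sapiens), read by a luciferase reporter and beta-arrestin recruitment, with a stated time of 10 min (a higher number here means a larger maximal response, a lower number a smaller maximal response), compound 1 gives 37% and is the only compound of the three for which a number is reported; for compound 2 the result is "not determined" (no result reported) and for compound 3 it is "not determined" (no result reported). Compound 4 `Cc1cc(Br)ccc1C(=O)Nc1ccc(S(=O)(=O)Nc2ccccc2)cc1` has not yet been measured. It differs from compound 1 in one place: 4-bromo-2-methylphenyl in place of 4-chloro-2,5-difluorophenyl on a carbonyl carbon. Going by the values given here, no pair of measured compounds differs in a single place, so no measured step is available to guide the expectation; the largest response of compound 1 is the only anchor. With nothing to point either way, the step is expected to stay within the usual scatter, estimated as a number 2 percentage points lower from compound 1 to compound 4 (within the scatter). Compound 4 is therefore expected to reach about 35%, with a wide range from 10% to 65%.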

Compound 4, largest response reached (Emax), in percent of the reference or control that the assay uses: 103%
Compound 4: the middle estimate sits 68 percentage points below what was measured; measured number outside the range, above it.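

In this assay, the group on the carbonyl carbon proves to have a strong influence on the largest response: with the rest of compound 1 unchanged, 4-bromo-2-methylphenyl in place of 4-chloro-2,5-difluorophenyl gives a number 66 percentage points higher from compound 1 to compound 4 (beyond the scatter). For the compounds shown here, the earlier compounds offered no such comparison, so this is the first sign that the position is sensitive to substitution. Nothing available explains the step. The compounds shown leave open which of the exchanged substituents accounts for it, since bromine, methyl, chlorine and fluorine changed together. As far as these compounds go, how a methoxy group or a nitrile would read on this ring also remains open.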